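The source may hold more compounds than are shown below. What is called first, only, known or untested is meant among the compounds shown, and "the series" means these compounds.

Measured in a functional assay on HT-29 cells (Homo sapiens) for inhibition; a higher number here means a weaker inhibitor, a lower number a stronger inhibitor:

Compound 1 `Oc1ccc(/C=C/c2ccc3ccccc3c2)cc1`: 4060 nM
Compound 2 `Cc1ccc(/C=C/c2ccc3ccccc3c2)cc1`: > 5000 nM

Compound 2 has no number in this assay. Its > 5000 nM is a limit of the assay. Among the measured compounds shown here, the series so far therefore rests on a single numerical value, with the limit of > 5000 nM in this assay, at which 1 of the 2 values shown sits.

Compound 3 `Cc1ccc(/C=C\c2ccc3ccccc3c2)cc1` is the next structure to consider, and the change from compound 2 is one of configuration alone: the two compounds have the same atoms and bonds and differ only in configuration as drawn: 1 of 1 stereo elements differ; a double bond is drawn E in compound 2 and Z in compound 3.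

For the measured compounds named here, only one measured step exists, an at least 1.2-fold higher number from compound 1 to compound 2 (0.09 log units; that floor lies within the scatter). It replaces hydroxy with methyl and leaves the configuration of the double bond untouched, so it gives no measure of the change at hand. Going by the values given here, no pair differing in configuration has been measured, which leaves neither a size nor a direction to carry over. The expectation is therefore no step beyond the scatter, with wide uncertainty and a real chance that compound 3 also returns only a limit.

Compound 3 is estimated at 4000 nM, with an expected range of 1200 nM to 10000 nM.

The estimate means an expected at least 1.2-fold lower number from compound 2 to compound 3 (0.09 log units; that floor lies within the scatter).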

Compound 3, half-maximal inhibitory concentration: > 5000 nM
Compound 3 ended at the assay's limit; the forecaster's own chance of this, stated with the estimate: 50%; middle value at least 1.2-fold (0.09 log units) away from the limit.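

In this assay compound 3 gives > 5000 nM, which is a limit of the assay. Compound 2 gives > 5000 nM, also a limit, so no step can be read between compound 2 and compound 3. The series now stands as follows: the limit of > 5000 nM in this assay, at which 2 of the 3 values shown sit. On these data alone, whether the E or Z configuration of the double bond changes inhibition in this assay stays open, and the pair bears on exactly that: the fact that compounds 2 and 3 differ only in the configuration as drawn.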